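Phenylsulfonyl on the ring amine of compound 3

A few compounds are considered here, and "the series" means these few. Any claim that something is new, unique, unknown or untested is made for them only; others in the source may bear on it.

In a functional assay on SF-268 cells (Homo sapiens) for cytotoxicity, read by MTT assay, with a stated time of 3 days (a lower number here means a stronger inhibitor, a higher number a weaker inhibitor), compound 1 (`N#Cc1c(O)nc(SCc2nc3ccccc3[nH]2)nc1-c1ccccc1`) gives 3.2 nM and compound 2 (`N#Cc1c(Cl)nc(SCc2nc3ccccc3[nH]2)nc1-c1ccccc1`) gives 3.2 nM, so the exchange of hydroxy for chloro shows no change at the digits printed from compound 1 to compound 2 (within the scatter). Compound 3 (`N#Cc1c(-c2ccccc2)nc(SCc2nc3ccccc3[nH]2)nc1N1CCNCC1`) gives 20000 nM, the highest of the three numbers. Placing piperazin-1-yl on the same aromatic carbon accounts for both large steps, a 6300-fold higher number from compound 1 to compound 3 (3.80 log units; beyond the scatter) and a 6300-fold higher number from compound 2 to compound 3 (3.80 log units; beyond the scatter).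

Compound 4 (`N#Cc1c(-c2ccccc2)nc(SCc2nc3ccccc3[nH]2)nc1N1CCN(S(=O)(=O)c2ccccc2)CC1`) keeps that piperazin-1-yl group and carries phenylsulfonyl in place of hydrogen on an amine nitrogen in a ring. Going by the values given here, no measured step involves a change at this nitrogen, so the series gives only indirect guidance. The nearest evidence is a 6300-fold higher number from compound 1 to compound 3 (3.80 log units; beyond the scatter) and a 6300-fold higher number from compound 2 to compound 3 (3.80 log units; beyond the scatter), which show how far the number can move when the substituent on that carbon changes. Neither step shows whether substitution on the ring nitrogen recovers any of that loss. Compound 3 stands at 20000 nM, and a moderate move toward lower numbers is the tentative expectation, with no return to the level of compound 1 assumed. The expected change is an 8.0-fold lower number from compound 3 to compound 4 (0.90 log units; beyond the scatter), with wide uncertainty. For compound 4, the estimated value is 2500 nM, with an expected range from 150 nM to 30000 nM.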

Compound 4, half-maximal inhibitory concentration: 2.87 nM
Estimate against measurement, compound 4: 870-fold (2.94 log units) above, outside the stated range (below it).
By their numbers in this assay, from the lowest: compounds 4, 1 and 2 (each within the scatter of the next); then compound 3.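

In this assay, going by these compounds alone, the amine nitrogen in the six-membered non-aromatic ring proves to be a highly sensitive position, a point that the earlier compounds, all unsubstituted or lacking this ring, could not establish: phenylsulfonyl in place of hydrogen gives a 7000-fold lower number from compound 3 to compound 4 (3.84 log units; beyond the scatter). This step runs opposite in direction to a 6300-fold higher number from compound 1 to compound 3 (3.80 log units; beyond the scatter), so the high number of compound 3 does not hold for every compound bearing piperazin-1-yl, and a substituent on the ring nitrogen can change the reading in this assay decisively. The compounds shown carry no evidence on why the number moves so far at this nitrogen.

From the compounds shown here alone, what remains open is which part of the entering group matters, the sulfonyl link or the phenyl ring: methanesulfonyl, benzoyl or benzyl on the same nitrogen would separate the two. Also open, going by these compounds, is how much the phenyl ring of the phenylsulfonyl group tolerates further change, for example a methoxy group or a chlorine atom on that ring, and whether a small alkyl group such as methyl on the nitrogen would produce any comparable step.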